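The compounds below may be only part of what the source reports. "The series", "measured", "known", "first", "only" and "open" are said of these compounds alone.

Of the compounds shown here, three share one core and have been tested in a functional assay on MCF7 cells (Homo sapiens) for cytotoxicity, read by CCK-8 assay, with a stated time of 72 h; on this read-out higher numbers stand for weaker inhibition and lower numbers for stronger inhibition. Compound 1 `C=CCn1c(=O)/c(=C\c2ccccc2OC)[nH]c(=O)/c1=C\c1ccccc1OC` carries two methoxyphenyl groups and in this assay gives 41100 nM. Compound 2 `C=CCn1c(=O)/c(=C\c2ccc(F)c(Br)c2)[nH]c(=O)/c1=C\c1ccccc1OC`, with a bromofluorophenyl group in place of one of them, is recorded in this assay as "not active" (no number reported). Compound 3 `C=CCn1c(=O)/c(=C\c2ccc(C)cc2)[nH]c(=O)/c1=C\c1ccccc1OC`, with a 4-methylphenyl group at the same place, is likewise recorded in this assay as "not active" (no number reported). So compound 3 stands without a number at all, and only compound 1 offers a measured value, itself a weak one.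

Compound 4 `C=CCn1c(=O)/c(=C\c2cccc(C)c2)[nH]c(=O)/c1=C\c1ccccc1OC` differs from compound 3 in one respect: 3-methylphenyl in place of 4-methylphenyl on a double-bonded chain carbon bound to an aromatic carbon. The two have the same atoms joined differently. No step between measured compounds is available to anchor this move, and nothing in the shown results suggests that such a small rearrangement should lift activity much beyond what compound 1 shows. Compound 4 is therefore expected to remain weak, near 60000 nM, with a range from 20000 nM to 200000 nM, and quite possibly to be reported without a number.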

Compound 4, half-maximal inhibitory concentration: 20700 nM
Compound 4: the middle estimate sits 2.9-fold (0.46 log units) above what was measured, and the stated range covers the measured number.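

With 3-methylphenyl on a double-bonded chain carbon bound to an aromatic carbon, compound 4 gives a number in this assay (20700 nM), whereas compound 3, with 4-methylphenyl at that place, is recorded as "not active", so moving the methyl group separates a reading with a number from one without. Replacing 2-methoxyphenyl with 3-methylphenyl gives a 2.0-fold lower number from compound 1 to compound 4 (0.30 log units; within the scatter), so this change leaves no real difference between the two compounds in this test, and a methoxy group at that place is not needed for a measurable reading. Nothing available explains why the two methylphenyl groups behave differently.

From the compounds shown here alone, it remains open how 2-methylphenyl would read at the same place, which would complete the series of methyl placements. Going by these compounds, it is also open whether a larger group, such as 3-ethylphenyl, or an amine, as in 3-aminophenyl, would bring a clearly lower number.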